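Tail truncation in a shared-core series: hydrazide to primary amide

The source may report more compounds than this note shows. Statements on the series, on what has been measured and on what is new or still open speak of the compounds shown alone.

Measured compounds:
compound 1, `CC[C@H](C)[C@H](NC(=O)c1cccc(Cn2ccnc2)c1)C(=O)NNC(=O)OC(C)(C)C`, an assay on HEK293 cells for displacement of a labelled ligand from Type-2 angiotensin II receptor (Homo sapiens), tested at 10 uM; on this read-out lower numbers stand for a weaker effect and higher numbers for a stronger effect at the one concentration tested: "not determined" (no result reported)
compound 2, `CC[C@H](C)[C@H](NC(=O)c1cccc(Cn2ccnc2)c1)C(=O)Nc1nccs1`, this assay: 17%
compound 3, `CCCCCS(=O)(=O)NNC(=O)[C@@H](NC(=O)c1cccc(Cn2ccnc2)c1)[C@@H](C)CC`, this assay: "not determined" (no result reported)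

Compound 3 stands without a number in this assay; the same holds for compound 1. For the measured compounds named here, of the shared core, only compound 2 has a reported value, and it is a single-concentration read-out with no step to any other compound, so nothing of the size of a change can be drawn from two measured points. The next compound, compound 4, `CC[C@H](C)[C@H](NC(=O)c1cccc(Cn2ccnc2)c1)C(N)=O`, differs from compound 3 in one place: hydrogen in place of (pentylsulfonyl)amino on an amide-type nitrogen. Going by the values given here, no measured step bears on this change, and compound 3 itself gives no number to step from. The expectation for this assay is therefore anchored only on compound 2, whose value 17% is the sole read-out of the core; no direction beyond the scatter is expected, and a modest read-out in the same region is the estimate. Compound 4 is expected to give about 15%, with a range from 0% to 40%.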

Compound 4, a percentage reported as inhibition, at one concentration (the size of the read-out at that concentration, not a potency): "not active" (no number reported)
The entry for compound 4 holds no number; the estimate stays without a comparison.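

In this assay compound 3 gives "not determined" (no result reported) and compound 4 gives "not active" (no number reported) so no step can be read between compound 3 and compound 4. As far as these compounds go, whether replacing (pentylsulfonyl)amino with hydrogen changes the read-out stays open. No supporting data bear on the entry for compound 4.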